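A few compounds are considered here, and "the series" means these few. Any claim that something is new, unique, unknown or untested is made for them only; others in the source may bear on it.

Compound 1 `COc1ccc(/C=C2\S/C(=N\c3ccc(C(C)(C)C)cc3)N(C)C2=O)cc1` gives > 100000 nM in a functional assay on MCF7 cells (Homo sapiens) for antiproliferative activity, read by MTT assay, with a stated time of 72 h (on this read-out higher numbers stand for weaker inhibition and lower numbers for stronger inhibition), which is a limit of the assay and not a number.
Compound 2 `COc1ccc(/C=C2/CN(C)/C(=N/c3ccc(Cl)cc3)S2)cc1` gives 7600 nM in this assay.
Compound 3 `COc1ccc(/C=C2/CN(C)/C(=N/c3ccc(F)cc3)S2)cc1` gives 8000 nM in this assay.

Of the three values, compound 1 is the one that sits at a limit, (the limit of > 100000 nM in this assay, at which 1 of the 3 values shown sits), so its potency is known only as a bound. Compound 4 `COc1ccc(/C=C2\S/C(=N\c3ccc(Cl)cc3)N(C)C2=O)cc1` has not yet been measured. It differs from compound 1 in one place: chloro in place of tert-butyl on an aromatic carbon. For the measured compounds named here, the one measured step, a 1.1-fold higher number from compound 2 to compound 3 (0.02 log units; within the scatter), exchanges one halogen for another on a core that is not the core of compound 1, and it lies within the scatter, so it offers no guide to the size of a change from tert-butyl to chloro. Between compound 1 and compound 2 no single step is shown; compound 2 carries chloro on a different core and gives a measurable number. Any expectation for compound 4 therefore rests on little, and the step of an at least 2.5-fold lower number from compound 1 to compound 4 (0.39 log units; beyond the scatter) is an estimate only. Compound 4 is expected to give about 40000 nM in this assay, within a range from 8000 nM to 150000 nM, with a real chance that only a limit is reported again.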

Compound 4, half-maximal inhibitory concentration: 39300 nM
Estimate against measurement, compound 4: 1.0-fold (0.01 log units) above, and the stated range covers the measured number.
By their numbers in this assay, from the lowest: compounds 2 and 3 (each within the scatter of the next); then compound 4. At a limit, above all of these: compound 1.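

Exchanging tert-butyl for chloro on this aromatic carbon turns a limit into a measurable number on the core of compound 1 in this assay, giving an at least 2.5-fold lower number from compound 1 to compound 4 (0.40 log units; beyond the scatter). The earlier exchange of one halogen for another, a 1.1-fold higher number from compound 2 to compound 3 (0.02 log units; within the scatter), stayed within the scatter on a different core, so this is the first change shown that moves the read-out beyond the scatter, and it shows that the group at this place can matter on this core. Going by these compounds, the true size of the step remains unknown because compound 1 stands at a limit, and a limit is not a number: the limit of > 100000 nM in this assay, at which 1 of the 4 values shown sits.

With only tert-butyl and chloro shown on this core, it remains open how the read-out would respond to other groups at this place, such as an amine, a carboxylic acid or a longer carbon chain. Also open, on these data alone, is how much the core itself counts: with chloro on each core, compound 4 gives 39300 nM and compound 2 gives 7600 nM, but a single pair cannot show whether the two cores would compare in the same way with other groups.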